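Mirror-image dioxane ring and permeability across a cell layer

The source may hold more compounds than are shown below. What is called first, only, known or untested is meant among the compounds shown, and "the series" means these compounds.

Of the compounds shown here, three sharing one core have been measured in an ADME assay on MDCKII-LE cells (Canis lupus familiaris) for permeability, read by transwell migration, in the apical to basolateral direction; a lower number here means that the compound crosses the layer more slowly, a higher number that the compound crosses the layer faster. Compound 1 `NC(=O)[C@@H](CCC(F)(F)F)N(CC1CCCC1)S(=O)(=O)c1ccc(Cl)cc1` gives 6.01 10^-6 cm/s. Compound 2 `NC(=O)[C@@H](CCC(F)(F)F)N(C[C@@H]1CCCCO1)S(=O)(=O)c1ccc(Cl)cc1` gives 15.4 10^-6 cm/s, and compound 3 `NC(=O)[C@@H](CCC(F)(F)F)N(C[C@@H]1COCCO1)S(=O)(=O)c1ccc(Cl)cc1` gives 27.3 10^-6 cm/s, the largest of the three numbers; the step of a 4.5-fold higher number from compound 1 to compound 3 (0.66 log units; beyond the scatter) lies beyond the scatter, whereas a 1.8-fold higher number from compound 2 to compound 3 (0.25 log units; within the scatter) does not. Compound 4 `NC(=O)[C@@H](CCC(F)(F)F)N(C[C@H]1COCCO1)S(=O)(=O)c1ccc(Cl)cc1` keeps every atom and bond: the two compounds have the same atoms and bonds and differ only in configuration as drawn: 1 of 2 stereo elements differ; a stereocentre at a saturated ring carbon is drawn R in compound 3 and S in compound 4. Among the compounds with values here, none of the measured steps swaps one mirror form for another; each exchanges one ring for a different ring, such as a 2.6-fold higher number from compound 1 to compound 2 (0.41 log units; beyond the scatter). These data therefore give no direction for the change, and no step beyond the scatter is expected; the estimated step of a 1.0-fold lower number from compound 3 to compound 4 (0.00 log units; within the scatter) is small. Compound 4 is estimated at 27 10^-6 cm/s, between 14 10^-6 cm/s and 50 10^-6 cm/s.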

Compound 4, apparent permeability: 20.6 10^-6 cm/s
Beside the measured number, compound 4's estimate is 1.3-fold (0.12 log units) above it; the measured number falls inside the stated range.
By their numbers in this assay, from the lowest: compound 1; then compounds 2, 4 and 3 (each within the scatter of the next).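

Within the data shown here, at this ring carbon, the R and S forms stay within the scatter of each other in this assay (a 1.3-fold lower number from compound 3 to compound 4 (0.12 log units; within the scatter)), the first reading of configuration alone in this set: the fact that compounds 3 and 4 differ only in the configuration as drawn. The S form also stays within the scatter of the oxan-2-yl ring (a 1.3-fold higher number from compound 2 to compound 4 (0.13 log units; within the scatter)) and lies beyond the scatter above the cyclopentyl ring (a 3.4-fold higher number from compound 1 to compound 4 (0.53 log units; beyond the scatter)), so the gain over cyclopentyl holds for both mirror forms of the 1,4-dioxan-2-yl group.

On these data alone, whether reversing the configuration of the oxan-2-yl ring gives the same result stays open, as does the effect of an amine or a carboxylic acid on that ring.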